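A few compounds are considered here, and "the series" means these few. Any claim that something is new, unique, unknown or untested is made for them only; others in the source may bear on it.

Compound 1, `CCOC(=O)c1ccc(CO/N=C/c2c(C)nn(C)c2Oc2ccc(Cl)cc2)cc1`: 48.2%
Compound 2, `CCOC(=O)c1ccc(CO/N=C/c2c(C)nn(-c3ccccc3)c2Oc2ccc(Cl)cc2)cc1`: -9.9%

Going by the values given here, in a functional assay on A549 cells (Homo sapiens) for antiproliferative activity, tested at 1 uM (a lower number here means less inhibition, a higher number more inhibition at the concentration tested (going by the name of the read-out)), compound 1 gives 48.2%, the highest of the two numbers measured so far. Compound 2 gives -9.9%. Among the compounds with values here, the only measured step, a number 58.1 percentage points lower from compound 1 to compound 2 (beyond the scatter), came from putting phenyl in place of methyl on an aromatic nitrogen, a change at the core of the shared structure.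

Compound 3, `COC(=O)c1ccc(CO/N=C/c2c(C)nn(C)c2Oc2ccc(Cl)cc2)cc1`, is not yet measured. It differs from compound 1 by hydrogen in place of methyl on a saturated chain carbon bound to an oxygen next to a carbonyl group, that is, ethoxycarbonyl to methoxycarbonyl at the far end of the molecule. Within the data shown here, no measured step touches this ester end, so the large step seen between compound 1 and compound 2 does not bear on it. With nothing to suggest otherwise, a change this small is expected to give a step of about a number 3.2 percentage points lower from compound 1 to compound 3 (within the scatter) in this assay, within the usual scatter. Compound 3 is therefore estimated at 45%, with a range from 25% to 65%.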

Compound 3, a percentage reported as inhibition, at one concentration (the size of the read-out at that concentration, not a potency): 49.9%
Beside the measured number, compound 3's estimate is 4.9 percentage points below it; low and high end bracket the measured number.
By their numbers in this assay, from the lowest: compound 2; then compounds 1 and 3 (each within the scatter of the next).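

In this assay, going from ethoxycarbonyl to methoxycarbonyl gives a number 1.7 percentage points higher from compound 1 to compound 3 (within the scatter) and so leaves the read-out unchanged for practical purposes. The earlier step, a number 58.1 percentage points lower from compound 1 to compound 2 (beyond the scatter) on the aromatic nitrogen, showed that one part of the molecule matters strongly; this result adds that removing a single methyl at the ester end does not produce a readable difference. Nothing measured here gives a reason for this contrast.

A single small trim says little about the ester end as a whole: a longer chain such as propyl, a carboxylic acid or an amide there could behave quite differently. From the compounds shown here alone, it also remains open whether the same ethyl to methyl change would go unnoticed on compound 2, which carries phenyl on the aromatic nitrogen.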